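The source may report more compounds than this note shows. Statements on the series, on what has been measured and on what is new or still open speak of the compounds shown alone.

Compound 1 `COc1cccc(NC(=O)CSCn2[nH]nc3c(=O)nc(Cc4ccc(F)cc4)nc2-3)c1` was tested in an assay on cells for inhibition of uridine-cytidine kinase 2 (Homo sapiens), read by ADP-Glo, with stated times of 15 min and 60 min (on this read-out lower numbers stand for stronger inhibition and higher numbers for weaker inhibition), and came out as "not active" (no number reported), so it offers no number to anchor a comparison. A related compound 2 `O=C(CSc1nc2n(-c3ccc(F)cc3)[nH]cc-2c(=O)n1)Nc1ccc(Br)cc1` in this assay gives 16400 nM, a weak result. Compound 3 `Cc1ccccc1NC(=O)CSCn1[nH]nc2c(=O)nc(Cc3ccc(F)cc3)nc1-2` differs from compound 1 by a single change: 2-methylphenyl in place of 3-methoxyphenyl on an amide-type nitrogen. Going by the values given here, no measured pair shows the effect of this change, so the expected step in this assay is small and without a clear direction, probably no larger than the scatter. Compound 3 is therefore expected to be weak as well, estimated at 30000 nM with a range from 10000 nM to 100000 nM.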

Compound 3, half-maximal inhibitory concentration: 137000 nM
Estimate against measurement, compound 3: 4.6-fold (0.66 log units) below; the whole stated range lies below it.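

Compound 1 has no number to compare, so no step to compound 3 can be read, and nothing shown here accounts for the result. In this assay the compounds shown leave open how replacing 3-methoxyphenyl with 2-methylphenyl changes inhibition.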